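A few compounds are considered here, and "the series" means these few. Any claim that something is new, unique, unknown or untested is made for them only; others in the source may bear on it.

Measured in a functional assay on OVCAR-8 cells (Homo sapiens) for antiproliferative activity; a lower number here means a stronger inhibitor, a higher number a weaker inhibitor:
Compound 2, `Cn1ncc(Cl)c1-c1cc(C(=O)N[C@@H]2CN[C@H](CCN3CCCC3)C[C@H]2c2ccc(Cl)c(Cl)c2)oc1Cl`: 1840 nM
Compound 1, `Cn1ncc(Cl)c1-c1cc(C(=O)N[C@H]2CNCC[C@@H]2c2ccc(C(F)(F)F)cc2)oc1Cl`: 900 nM

Compound 2 has the highest number of the two measured in this assay; its nearest neighbour is compound 1, whose number is lower by an amount beyond the usual scatter. Compound 3, `CN(C)CC[C@@H]1C[C@@H](c2ccc(Cl)c(Cl)c2)[C@H](NC(=O)c2cc(-c3c(Cl)cnn3C)c(Cl)o2)CN1`, has not yet been measured. It differs from compound 2 in one place: dimethylamino in place of pyrrolidin-1-yl on a saturated chain carbon, two bonds along the chain from a saturated ring carbon. For the measured compounds named here, no step between measured compounds shows what this swap does, so no step beyond the scatter is expected in this assay, in either direction. Compound 3 is therefore estimated at 1800 nM (range 700 nM to 4500 nM), an expected step of a 1.0-fold lower number from compound 2 to compound 3 (0.01 log units; within the scatter).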

Compound 3, half-maximal inhibitory concentration: 1510 nM
The estimate for compound 3 lay 1.2-fold (0.08 log units) above the measured number; low and high end bracket the measured number.
By their numbers in this assay, from the lowest: compounds 1, 3 and 2 (each within the scatter of the next, the first and the last beyond it).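

In this assay, dimethylamino in place of pyrrolidin-1-yl gives a 1.2-fold lower number from compound 2 to compound 3 (0.09 log units; within the scatter), so the two compounds cannot be told apart. At this place on the chain, the ring of pyrrolidin-1-yl can therefore give way to an open, smaller amine without a step beyond the scatter. Nothing available explains this result. On these data alone, what stays open is whether this place tolerates any group, or only these two amines: a morpholine, a primary amine or a carboxylic acid at the chain end could answer that. A longer chain remains equally untested here.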